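This account rests on a few compounds, and the source may have more. Where it says the series, first, only, none or still open, it means among the compounds named here.

- compound 1 `CC1CCN(c2ccc(NC(=O)c3ccc(OCCCCl)c([N+](=O)[O-])c3)cn2)CC1`: 9200 nM
- compound 2 `CC(C)Oc1ccc(C(=O)Nc2ccc(N(C)C)cc2)cc1NC(=O)C(C)Br`: 7900 nM
- compound 3 `COc1ccc(NC(=O)c2ccc(OCCCN(C)C)c([N+](=O)[O-])c2)cc1`: 127000 nM

All three values come from a toxicity assay on Huh-7.5 cells (Homo sapiens) for inhibition, read by MTT assay, with a stated time of 96 h; on this read-out lower numbers stand for higher toxicity in this test and higher numbers for lower toxicity in this test. Compound 3 stands highest of the three at 127000 nM, and its gaps to compound 1 and to compound 2 both lie beyond the usual scatter of repeated measurements.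

The next compound, compound 4 `COc1ccc(NC(=O)c2ccc(OCCCCl)c([N+](=O)[O-])c2)cc1`, differs from compound 3 in one place: chloro in place of dimethylamino on a saturated chain carbon, three bonds along the chain from an oxygen on an aromatic ring. Put another way, 3-(dimethylamino)propyl becomes 3-chloropropyl.

Within the data shown here, no two measured compounds differ in only one place, so the size of this change has not been seen directly. The closest guide is compound 1, which carries the same 3-chloropropyl chain, though the rest of its structure differs, and which gives 9200 nM. On that basis, a lower number in this assay is expected, meaning higher toxicity in this test, by a step beyond the scatter. The expected size of the move is a 6.4-fold lower number from compound 3 to compound 4 (0.80 log units; beyond the scatter). For compound 4 the estimated value is 20000 nM, with an expected range from 7000 nM to 70000 nM.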

Compound 4, half-maximal cytotoxic concentration: 39700 nM
For compound 4 the middle estimate is 2.0-fold (0.30 log units) below the measured one; the measured number falls inside the stated range.
By their numbers in this assay, from the lowest: compounds 2 and 1 (each within the scatter of the next); then compound 4; then compound 3.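

Among these compounds, this pair gives the first direct reading of this position in this assay: on a saturated chain carbon, three bonds along the chain from an oxygen on an aromatic ring, chloro in place of dimethylamino gives a 3.2-fold lower number from compound 3 to compound 4 (0.51 log units; beyond the scatter). The step is modest, and it points to higher toxicity in this test. Since the rest of the structure is shared, the earlier spread among compounds with different structures now gains one clean comparison, showing that the end of this chain alone can shift the read-out, while no measurement here explains why the number moves with this swap.

A single pair cannot show whether the outcome follows from losing dimethylamino or from gaining chloro, and a hydroxyl group, a morpholine ring or a longer chain at the same place could land anywhere relative to these two compounds. From the compounds shown here alone, it also remains open whether 3-(dimethylamino)propyl to 3-chloropropyl would produce a step of similar size on a different core, such as the core of compound 1.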